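Cytotoxicity Outlook for a Methoxyphenyl Carbonyl Analogue

This account rests on a few compounds, and the source may have more. Where it says the series, first, only, none or still open, it means among the compounds named here.

Compound 1 `Cc1ccc(C(=O)Nc2ncc(Cc3ccc(F)cc3)s2)cc1`: "not toxic" (no number reported)
Compound 2 `Cc1cc(C(C)C)ccc1OC(c1ccc(Cl)cc1)c1cnc(NC(=O)OC(C)(C)C)s1`: > 50000 nM
Compound 3 `O=C(Nc1ncc(C(Oc2ccc3cc(Br)ccc3c2)c2ccc(Cl)cc2)s1)c1cccs1`: "not toxic" (no number reported)

In an ADME assay on HepG2 2.2.15 cells (Homo sapiens) for cytotoxicity (a higher number here means that more compound is tolerated, a lower number that less compound is tolerated), compound 1 gives "not toxic" (no number reported). Compound 2 reaches only a limit of the assay, > 50000 nM. Compound 3 gives "not toxic" (no number reported), so no single number stands for it. Beside compound 3 sit one further entry without a number and the one value of compound 2 that is a limit of the assay, namely (the limit of > 50000 nM in this assay, at which 1 of the 3 values shown sits). Compound 4 `COc1ccc(C(=O)Nc2ncc(C(Oc3ccc4cc(Br)ccc4c3)c3ccc(Cl)cc3)s2)cc1` differs from compound 3 in one place: 4-methoxyphenyl in place of thiophen-2-yl on a carbonyl carbon. Within the data shown here, no step between two measured compounds is available, so the change cannot be sized from the data. In this assay the step from compound 3 to compound 4 is expected to be none beyond the scatter. Compound 4 is estimated at 50000 nM, with a range from 20000 nM to 100000 nM, and is expected most likely to be reported only as a limit.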

Compound 4, half-maximal cytotoxic concentration: > 50000 nM
Compound 4 ended at the assay's limit (the forecaster's own chance of this, stated with the estimate: 80%); the middle value sits exactly at the limit.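

In this assay compound 4 gives > 50000 nM, which is a limit of the assay. Among these compounds, compound 3 has "not toxic" (no number reported), so no step between compound 3 and compound 4 can be read. The compounds shown leave open what concentration of any of them would prove toxic to these cells.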